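Removing bromine and methoxy from an inactive benzamide

The compounds below may be only part of what the source reports. "The series", "measured", "known", "first", "only" and "open" are said of these compounds alone.

Three compounds share an amide built from a benzoic acid and an aniline. Compound 1 `COc1c(Br)cc(Br)cc1C(=O)Nc1ccccc1`, compound 2 `O=C(Nc1cccc(Cl)c1)c1ccccc1O` and compound 3 `COc1ccc(Br)cc1C(=O)Nc1ccc(Sc2nc3ccccc3s2)cc1` were each tested in an assay for inhibition of HSP60/HSP10 (Homo sapiens), with a stated time of 60 min; a lower number here means a stronger inhibitor, a higher number a weaker inhibitor. In this assay compound 1 gives > 100000 nM, a limit of the assay rather than a number. Compound 2 likewise gives > 100000 nM, again only a limit. Compound 3 gives > 100000 nM, also a limit and not a measured number, so compound 3 stands at the edge of what the assay can report, together with the other two, as shown by the limit of > 100000 nM in this assay, at which 3 of the 3 values shown sit.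

Compound 4 `O=C(Nc1ccc(Sc2nc3ccccc3s2)cc1)c1ccccc1` has not yet been measured. It differs from compound 3 by phenyl in place of 5-bromo-2-methoxyphenyl on a carbonyl carbon, so the bromine and the methoxy group are gone. Among the compounds with values here, since all three known values sit at the limit, there is no measured step to guide the direction. The step from compound 3 to compound 4 is expected to be a step that the limit leaves unreadable from compound 3 to compound 4, meaning no change beyond the scatter. Compound 4 is therefore estimated at 150000 nM, between 50000 nM and 500000 nM, most likely reported again only as a limit.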

Compound 4, half-maximal inhibitory concentration: > 100000 nM
Compound 4 was reported as a limit (the forecaster's own chance of this, stated with the estimate: 85%); the middle value lies beyond the limit too.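

No step can be read between compound 3 and compound 4, because both results are limits of the assay and not numbers: the limit of > 100000 nM in this assay, at which 4 of the 4 values shown sit.

The compounds shown leave open which change to the shared core, if any, would bring a measurable value in this assay.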